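The compounds below may be only part of what the source reports. "The series", "measured", "known", "first", "only" and "open" are said of these compounds alone.

Compound 1 `Nc1ccc(/C=C2\SC(=O)N(Cc3ccc(C(F)(F)F)cc3)C2=O)cc1` gives 96000 nM in a functional assay on HeLa cells (Homo sapiens) for cytotoxicity, read by cell counting, with a stated time of 4 days; on this read-out lower numbers stand for stronger inhibition and higher numbers for weaker inhibition.
Compound 2 `C=C(Br)C(=O)Nc1ccc(/C=C2\SC(=O)N(Cc3ccc(C(F)(F)F)cc3)C2=O)cc1` gives 13000 nM in this assay.
Compound 3 `Nc1cccc(/C=C2\SC(=O)N(Cc3ccc(C(F)(F)F)cc3)C2=O)c1` reaches only a limit of the assay, > 250000 nM, in this assay.

Among the numbers shown, compound 1 stands highest of the two; the nearest is reached by a 7.4-fold lower number from compound 1 to compound 2 (0.87 log units; beyond the scatter). Compound 3 sits at the limit of > 250000 nM in this assay, at which 1 of the 3 values shown sits. The other measured step, an at least 2.6-fold higher number from compound 1 to compound 3 (0.41 log units; beyond the scatter), moves the amine to a different position on its ring.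

Compound 4 `Nc1ccc(/C=C2\SC(=O)N(Cc3ccccc3)C2=O)cc1` has not been measured. It differs from compound 1 by hydrogen in place of trifluoromethyl on an aromatic carbon. Neither measured step touches this group: one alters the nitrogen on the aromatic ring, the other moves that amine, and both leave the trifluoromethyl in place. There is therefore no measured guide to the size or direction of this change, and no step beyond the scatter is expected in this assay, although the uncertainty is wide.

Compound 4 is expected to give about 130000 nM, within 40000 nM to 400000 nM. This corresponds to an expected step of a 1.4-fold higher number from compound 1 to compound 4 (0.13 log units; within the scatter).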

Compound 4, half-maximal inhibitory concentration: 46000 nM
For compound 4 the middle estimate is 2.8-fold (0.45 log units) above the measured one; the measured number falls inside the stated range.
By their numbers in this assay, from the lowest: compound 2; then compound 4; then compound 1. At a limit, above all of these: compound 3.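

In this assay, hydrogen in place of trifluoromethyl gives a 2.1-fold lower number from compound 1 to compound 4 (0.32 log units; beyond the scatter). Among these compounds, this is the first measured change on this aromatic carbon, as the earlier steps altered only the amine end of the molecule, and it shows that the trifluoromethyl is not needed for the cytotoxicity of compound 1: without it, inhibition is modestly stronger, not weaker. Nothing in the data shown explains this direction.

Going by these compounds, a single replacement gives only one point at this position, so it remains open how a methyl, a methoxy or a chlorine atom on the same carbon would behave. On these data alone, it also remains open whether removing the trifluoromethyl would have a similar effect on compound 2, which carries the (1-bromoethenyl)carbonyl group on its nitrogen.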